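This account rests on a few compounds, and the source may have more. Where it says the series, first, only, none or still open, it means among the compounds named here.

Measured in a functional assay on NCI-H226 cells (Homo sapiens) for antiproliferative activity, read by sulforhodamine B assay, with a stated time of 48 h (on this read-out higher numbers stand for weaker inhibition and lower numbers for stronger inhibition), so far:
- compound 1 `C/C=C(\C)C(=O)O[C@H]1C=CC(=O)O[C@H]1CCC(=O)[C@H](C)O` gives 26000 nM
- compound 2 `C/C=C(\C)C(=O)O[C@H]1C=CC(=O)O[C@H]1COC(=O)[C@H](C)O` gives 19000 nM

Within the data shown here, compound 2 stands within the scatter of compound 1, the only other measured compound, so the two cannot be ranked. Compound 3 `C/C=C(\C)C(=O)O[C@H]1C=CC(=O)O[C@H]1CNC(=O)[C@H](C)O` has not yet been measured. The structural change is ((1-hydroxyethyl)carbonyl)amino in place of ((1-hydroxyethyl)carbonyl)oxy on a saturated chain carbon bound to a saturated ring carbon. Among the measured compounds shown here, one measured step bears on it: a 1.4-fold lower number from compound 1 to compound 2 (0.14 log units; within the scatter), a change at the same place that stayed small. For the measured compounds named here, a single step is thin evidence, and no measured compound carries the amino group. In this assay, going by these compounds, no shift beyond the scatter is therefore expected, and the direction stays open. The expected step is a 1.2-fold higher number from compound 2 to compound 3 (0.06 log units; within the scatter). For compound 3 the estimated value is 22000 nM, with an expected range from 10000 nM to 50000 nM.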

Compound 3, half-maximal inhibitory concentration: 27000 nM
Beside the measured number, compound 3's estimate is 1.2-fold (0.09 log units) below it; low and high end bracket the measured number.
By their numbers in this assay, from the lowest: compounds 2, 1 and 3 (each within the scatter of the next).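

In this assay, ((1-hydroxyethyl)carbonyl)amino in place of ((1-hydroxyethyl)carbonyl)oxy gives a 1.4-fold higher number from compound 2 to compound 3 (0.15 log units; within the scatter) and in place of ((1-hydroxyethyl)carbonyl)methyl gives a 1.0-fold higher number from compound 1 to compound 3 (0.02 log units; within the scatter) on a saturated chain carbon bound to a saturated ring carbon. The series now holds carbon, oxygen and nitrogen as the linking atom at this place, and the three compounds cannot be ranked, even though the amino group counts one more hydrogen-bond donor and one fewer acceptor than the oxy group. No measurement here speaks to why the numbers stay together.

Open, going by these compounds, is whether a carboxylic acid, a primary amine or a longer chain in place of the 1-hydroxyethyl end would give a step beyond the scatter. Also open, on these data alone, is whether this position matters at all for the activity of the shared core.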